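Little Change Expected at a High Cytotoxicity Value

The compounds below may be only part of what the source reports. "The series", "measured", "known", "first", "only" and "open" are said of these compounds alone.

Compound 1 (`COc1ccc(NC(=O)Nc2cc(C)nc3ccccc23)cc1F`) gives > 25000 nM as a limit
Compound 2 (`Cc1cc(NC(=O)Nc2ccc(C(F)(F)F)cc2)c2ccccc2n1`) gives 23000 nM as a number

Both results come from an ADME assay on HepG2 cells (Homo sapiens) for cytotoxicity, with a stated time of 72 h (a lower number here means that less compound is needed, a higher number that more compound is needed for the effect), and cover only these two compounds. For compound 1 there is only a limit (the limit of > 25000 nM in this assay, at which 1 of the 2 values shown sits), not a number. For the measured compounds named here, that leaves compound 2 with 23000 nM as the only true number, so it has no second measured value to be ranked against.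

The next compound, compound 3 (`COc1ccc(NC(=O)Nc2cc(C)nc3ccccc23)cc1`), changes one group of compound 2 (methoxy in place of trifluoromethyl on an aromatic carbon): methoxy in place of trifluoromethyl on an aromatic carbon, para to a large group. Going by the values given here, no step between two measured compounds is available to show how much such a swap can matter. The expectation is a small step or none beyond the scatter, because compound 2 at 23000 nM already needs a great deal of compound. A result reported only as a limit is also quite possible. The expected step is a 1.1-fold higher number from compound 2 to compound 3 (0.04 log units; within the scatter) on this estimate. For compound 3 the estimate is 25000 nM with an expected range from 13000 nM to 45000 nM overall.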

Compound 3, half-maximal effective concentration: > 25000 nM
Compound 3 was reported as a limit; the forecaster's own chance of this, stated with the estimate: 55%; the middle value lies on the limit itself.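

In this assay, for the compounds shown here, methoxy in place of trifluoromethyl on an aromatic carbon, para to a large group, gives an at least 1.0-fold higher number from compound 2 to compound 3 (0.03 log units; that floor lies within the scatter), and this is the first step here between two compounds that differ in one place and can be read. Compound 3 is reported only as a limit, not a number, and it shares that limit with one other compound: the limit of > 25000 nM in this assay, at which 2 of the 3 values shown sit.

Methoxy at this place therefore brings no sign that less compound is needed for the effect, something the two earlier compounds alone could not show, though the true size of the step stays unknown.

The step from compound 1 to compound 3, hydrogen in place of fluoro on an aromatic carbon, cannot be read: both values are limits. Going by these compounds, it remains open whether a different group at the place where methoxy sits, such as an amine or a carboxylic acid, would bring the result down to a true number that could be compared directly with compound 2.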